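The source may report more compounds than this note shows. Statements on the series, on what has been measured and on what is new or still open speak of the compounds shown alone.

Measured compounds:
- compound 1 `Cc1nc(-c2ccccc2)c(C(=O)N2CCN(c3cccc(C(F)(F)F)c3)CC2)o1`: 153 nM
- compound 2 `CCCc1nc(-c2ccc(OC)cc2)c(C(=O)N2CCN(c3cccc(Cl)c3)CC2)o1`: "not active" (no number reported)
- compound 3 `CC(=O)Nc1cccc(-c2nc(C)oc2C(=O)N2CCN(c3cccc(Cl)c3)CC2)c1`: 208 nM

In a functional assay on HL-60 cells (Homo sapiens) for inhibition, read by MTT assay, with a stated time of 72 h (on this read-out lower numbers stand for stronger inhibition and higher numbers for weaker inhibition), compound 1 gives 153 nM. Compound 3 gives 208 nM in this assay, and the two numbers lie within the usual scatter of each other, so neither can be set apart from the other. Among the compounds with values here, compound 2 carries no number in this assay, only the report "not active" (no number reported), and it differs from compound 1 in more than one place, so it gives no single step to read.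

Compound 4 `COc1cc(OC)cc(N2CCN(C(=O)c3oc(C)nc3-c3ccccc3)CC2)c1` is not yet measured. It differs from compound 1 as follows: 3,5-dimethoxyphenyl in place of 3-(trifluoromethyl)phenyl on an amine nitrogen in a ring. Within the data shown here, no pair of measured compounds shows this change or any change at this position, so the size of the step has to be guessed from compound 1 alone. With nothing in the series pointing either way, a step from compound 1 to compound 4 that stays close to the scatter is expected, leaning toward a weaker value, so that a 2.0-fold higher number from compound 1 to compound 4 (0.29 log units; within the scatter) is the estimated step. For compound 4 a value of 300 nM is expected in this assay, within a range of 80 nM to 1500 nM.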

Compound 4, half-maximal inhibitory concentration: 19.2 nM
The estimate for compound 4 lay 16-fold (1.19 log units) above the measured number; the measured number lies below the stated range.
By their numbers in this assay, from the lowest: compound 4; then compounds 1 and 3 (each within the scatter of the next).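

In this assay, within the data shown here, 3,5-dimethoxyphenyl in place of 3-(trifluoromethyl)phenyl on the amine nitrogen in the ring gives an 8.0-fold lower number from compound 1 to compound 4 (0.90 log units; beyond the scatter), the first single change to be read, and it lies beyond the scatter. The number at this position therefore responds to the substituents on the phenyl ring, even though the leaving and entering groups have the same count of heavy atoms and the entering group adds hydrogen-bond acceptors. No measurement shown here accounts for the step.

Whether both methoxy groups are needed remains open, since a single 3-methoxyphenyl group or a 3,5-dihydroxyphenyl group is not among the compounds shown. Going by these compounds, it is also open whether the step carries over to a compound with another group on the shared core, such as the acetamide-bearing phenyl of compound 3.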